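One Ring Stereocentre on a Long Fluorinated Chain

The compounds below may be only part of what the source reports. "The series", "measured", "known", "first", "only" and "open" are said of these compounds alone.

In a functional assay on HeLa cells (Homo sapiens) for inhibition, read by sulforhodamine B assay, with a stated time of 48 h (a higher number here means a weaker inhibitor of growth, a lower number a stronger inhibitor of growth), compound 1 (`O=C(CCC(F)(F)C(F)(F)C(F)(F)C(F)(F)F)NCCCCCCCCCN[C@@H]1[C@H](O)[C@@H](O)[C@H](O)[C@H]2COC(=O)N21`) gives > 100000 nM, which is a limit of the assay. Compound 2 (`O=C(CCC(F)(F)C(F)(F)C(F)(F)C(F)(F)C(F)(F)C(F)(F)C(F)(F)C(F)(F)F)NCCCCCCCCCN[C@@H]1[C@H](O)[C@@H](O)[C@H](O)[C@H]2COC(=O)N21`) gives > 100000 nM, which is likewise only a limit. Compound 3 (`O=C(CCC(F)(F)C(F)(F)C(F)(F)C(F)(F)F)NCCCCCCCCCN[C@@H]1[C@H](O)[C@@H](O)[C@@H](O)[C@H]2COC(=O)N21`) gives 45000 nM. Compound 4 (`O=C(CCC(F)(F)C(F)(F)C(F)(F)C(F)(F)C(F)(F)C(F)(F)C(F)(F)C(F)(F)F)NCCCCCCCCCN[C@@H]1[C@H](O)[C@@H](O)[C@@H](O)[C@H]2COC(=O)N21`) is related to compound 2 as follows: the two compounds have the same atoms and bonds and differ only in configuration as drawn: 1 of 5 stereo elements differ; a stereocentre at a saturated ring carbon is drawn R in compound 2 and S in compound 4. For the measured compounds named here, one measured step bears on this change, an at least 2.2-fold lower number from compound 1 to compound 3 (0.34 log units; beyond the scatter), where the same R to S change occurs with a different fluorinated chain. Going by these compounds, compound 2 has no number of its own, so the true size remains open, but a lower number of modest size is expected. The expected step is an at least 2.2-fold lower number from compound 2 to compound 4 (0.34 log units; beyond the scatter). Compound 4 is estimated at 45000 nM, with an expected range of 15000 nM to 100000 nM.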

Compound 4, concentration for 50% growth inhibition: > 100000 nM
Compound 4: no number, only a limit; the forecaster's own chance of this, stated with the estimate: 35%; at least 2.2-fold (0.34 log units) between middle value and limit.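

In this assay compound 4 gives > 100000 nM, which is only a limit. For the compounds shown here, compound 2 also stands at a limit, so no step between compound 2 and compound 4 can be read. The compounds shown leave open whether this change in configuration alters growth inhibition with the fluorinated chain of compound 2 and compound 4.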